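A few compounds are considered here, and "the series" means these few. Any claim that something is new, unique, unknown or untested is made for them only; others in the source may bear on it.

In a functional assay on MDA-MB-231 cells (Homo sapiens) for antiproliferative activity, read by MTT assay, with a stated time of 96 h (a lower number here means a stronger inhibitor, a higher number a weaker inhibitor), compound 2 (`CC(C)=CCC/C(C)=C/CC/C(C)=C/CC[C@]1(C)CCc2c(C)c(OC(=O)Nc3ccccc3)c(C)c(C)c2O1`) gives > 10000 nM, which is a limit of the assay and not a number. Compound 1 (`CC(C)=CCC/C(C)=C/CC/C(C)=C/CC[C@]1(C)CCc2c(C)c(OC(=O)NS(=O)(=O)c3ccc(C)cc3)c(C)c(C)c2O1`) gives > 10000 nM, which is also a limit. Compound 3 (`CC(C)=CCC/C(C)=C/CC/C(C)=C/CC[C@]1(C)CCc2cc(OC(=O)Nc3ccccc3)c(C)c(C)c2O1`) gives > 10000 nM, again a limit. All three therefore stand at the limit of > 10000 nM in this assay, at which 3 of the 3 values shown sit.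

Compound 4 (`CC(C)=CCC/C(C)=C/CC/C(C)=C/CC[C@]1(C)CCc2c(C)c(OC(=O)NCc3ccccc3)c(C)c(C)c2O1`) carries benzyl in place of phenyl on an amide-type nitrogen of compound 2: benzyl in place of phenyl on an amide-type nitrogen. Among the compounds with values here, two measured steps bear on this change. The first, a step that the two limits leave unreadable from compound 1 to compound 2, alters the group on the same nitrogen, while the second, a step that the two limits leave unreadable from compound 2 to compound 3, puts hydrogen in place of methyl on an aromatic carbon. Neither has a readable size, so they offer no size or direction to carry over. No step beyond the scatter is expected for compound 4 because of the limit of > 10000 nM in this assay, at which 3 of the 3 values shown sit. The estimated change is a step that the limit leaves unreadable from compound 2 to compound 4, with no direction supported by the data. The expected value for compound 4 is 15000 nM, with an estimated range of 6000 nM to 40000 nM.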

Compound 4, half-maximal inhibitory concentration: 7200 nM
The estimate for compound 4 lay 2.1-fold (0.32 log units) above the measured number; low and high end bracket the measured number.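

Benzyl in place of phenyl on the amide-type nitrogen gives the first number in this assay that is not a limit, with compound 4 at 7200 nM. This change reads as an at least 1.3-fold lower number from compound 2 to compound 4 (0.14 log units; that floor lies within the scatter), and the change from the sulfonyl group reads as an at least 1.3-fold lower number from compound 1 to compound 4 (0.14 log units; that floor lies within the scatter). The true size of each step stays unknown, and the floors do not show a change beyond the scatter, because compound 1 and compound 2 each stand at a limit of the assay: the limit of > 10000 nM in this assay, at which 3 of the 4 values shown sit.

The compounds shown leave open whether a longer chain such as 2-phenylethyl on the same nitrogen would give a lower number than compound 4. They also leave open whether hydrogen in place of methyl on the aromatic carbon, a step that cannot be read between compound 2 and compound 3, would change the number with benzyl on the nitrogen.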